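N-substituent change on the amine of the quinone core

The compounds below may be only part of what the source reports. "The series", "measured", "known", "first", "only" and "open" are said of these compounds alone.

Measured so far:
compound 1 `CNC1=CC(=O)c2c(cnc(C)c2C)C1=O` — 46300 nM
compound 2 `CNC1=CC(=O)c2cc(C)ncc2C1=O` — 6020 nM

Both compounds were run in a functional assay on cells (Homo sapiens) for cytotoxicity, read by propidium iodide staining, with a stated time of 4 days; a lower number here means a stronger inhibitor, a higher number a weaker inhibitor. Compound 1 gives 46300 nM. For the measured compounds named here, compound 2 gives 6020 nM, the lowest of the two numbers, and its only neighbour in the set is compound 1, whose number is higher by the step of a 7.7-fold lower number from compound 1 to compound 2 (0.89 log units; beyond the scatter), a move made by hydrogen in place of methyl on an aromatic carbon.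

Compound 3 `Cc1cc2c(cn1)C(=O)C(NCl)=CC2=O` has not yet been measured. It differs from compound 2 by chloro in place of methyl on an amine nitrogen. Going by the values given here, no measured step touches the amine nitrogen; the one step in hand, a 7.7-fold lower number from compound 1 to compound 2 (0.89 log units; beyond the scatter), concerns an aromatic carbon and says nothing direct about the amine substituent. Among the compounds with values here, with no step bearing on this change, the expectation for compound 3 in this assay is a number near that of compound 2, with wide uncertainty in either direction. The step from compound 2 to compound 3 is expected to be about a 1.0-fold lower number from compound 2 to compound 3 (0.00 log units; within the scatter). Compound 3 is therefore estimated at 6000 nM, in a range from 1500 nM to 25000 nM.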

Compound 3, half-maximal inhibitory concentration: 5190 nM
Estimate against measurement, compound 3: 1.2-fold (0.06 log units) above; measured number inside the range.
By their numbers in this assay, from the lowest: compounds 3 and 2 (each within the scatter of the next); then compound 1.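

In this assay, for the compounds shown here, the amine nitrogen is now probed for the first time, and a 1.2-fold lower number from compound 2 to compound 3 (0.06 log units; within the scatter) shows that compounds 2 and 3 cannot be told apart when chloro stands in place of methyl at this position. Among the steps in hand, only the one on the aromatic carbon, a 7.7-fold lower number from compound 1 to compound 2 (0.89 log units; beyond the scatter), separates two compounds, so the amine nitrogen has not yet produced a step beyond the scatter. No evidence is available that explains the result for compound 3.

Going by these compounds, the two groups compared on the amine nitrogen share one heavy atom each, so the response to a longer chain such as propyl, to a ring such as phenyl, or to a plain hydrogen at this position remains open. Also open, on these data alone, is whether chloro in place of methyl on the amine nitrogen would read the same on the core of compound 1, which carries the additional methyl on an aromatic carbon, and whether a carboxylic acid or an amine on the end of such a chain would be read any differently.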